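A chloro group at a new place on the core

This account rests on a few compounds, and the source may have more. Where it says the series, first, only, none or still open, it means among the compounds named here.

Compound 1 `CO/N=C1/C(=O)N(CCCCCCC(=O)NO)c2ccccc21`: 730 nM
Compound 2 `CO/N=C1/C(=O)N(CCCCCCC(=O)NO)c2ccc(Cl)cc21`: 490 nM

Within the data shown here, in a functional assay on SW-620 cells (Homo sapiens) for antiproliferative activity, read by sulforhodamine B assay, with a stated time of 48 h (a higher number here means a weaker inhibitor, a lower number a stronger inhibitor), compound 1 gives 730 nM, which places it within the scatter of compound 2, the only other compound measured so far. Compound 3 `CO/N=C1/C(=O)N(CCCCCCC(=O)NO)c2c(Cl)cccc21` has not yet been measured. It differs from compound 1 by one change, (chloro in place of hydrogen on an aromatic carbon), which is chloro in place of hydrogen on an aromatic carbon, ortho to a fused ring and meta to a fused ring. Among the measured compounds shown here, the one measured step that bears on this is the same exchange made at a different carbon, a 1.5-fold lower number from compound 1 to compound 2 (0.17 log units; within the scatter), and no measured compound carries chloro at the new place, so the guide is a loose one. No step beyond the scatter is therefore expected in this assay. Compound 3 is estimated at 600 nM, with an expected range from 250 nM to 1400 nM. The expected change is a 1.2-fold lower number from compound 1 to compound 3 (0.09 log units; within the scatter).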

Compound 3, half-maximal inhibitory concentration: 260 nM
For compound 3 the middle estimate is 2.3-fold (0.36 log units) above the measured one, and the stated range covers the measured number.
By their numbers in this assay, from the lowest: compounds 3, 2 and 1 (each within the scatter of the next, the first and the last beyond it).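

In this assay, among these compounds, chloro in place of hydrogen on the aromatic carbon ortho to a fused ring and meta to a fused ring gives a 2.8-fold lower number from compound 1 to compound 3 (0.45 log units; beyond the scatter), the first step to pass beyond the scatter, though only a modest one. The same exchange at the other carbon gave a 1.5-fold lower number from compound 1 to compound 2 (0.17 log units; within the scatter) and so showed no effect of chloro that could be told from the scatter, whereas this position does show one. Nothing measured here accounts for the step at this position.

The compounds shown leave open whether the step belongs to chloro itself or would also appear with fluoro, methyl, methoxy or an amine on the same carbon. They also leave open whether it would persist with a longer chain carrying the hydroxamic acid.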